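Removing a methoxy group from a hydrazone: what to expect

The source may report more compounds than this note shows. Statements on the series, on what has been measured and on what is new or still open speak of the compounds shown alone.

Compound 1 `COc1cc(/C=N/Nc2nc3ccccc3s2)cc(OC)c1O` gives 36% in a physicochemical assay on cells (Homo sapiens), with a stated time of 18 h, tested at 1 uM; a lower number here means a stronger effect, a higher number a weaker effect of the compound at the concentration tested.
Compound 2 `COc1cc(/C=N/NC(=O)c2ccncc2)cc(O)c1O` gives 59% in this assay.
Compound 3 `COc1cc(/C=N/Nc2nc3ccccc3s2)ccc1O` gives 65% in this assay.

Compound 1 and compound 3 share a core and differ in one place: hydrogen in place of methoxy on an aromatic carbon. That change made a step of a number 29 percentage points higher from compound 1 to compound 3 (beyond the scatter), so the effect of the compound became weaker when the methoxy group was removed. Compound 2 has a different core; the difference between the two cores is not broken down here. The values of compound 2 and compound 3 lie close together, while compound 1 stands apart from compound 2 with a lower number.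

Compound 4 `O=C(N/N=C/c1ccc(O)c(O)c1)c1ccncc1` has not yet been measured. It differs from compound 2 in this way: hydrogen in place of methoxy on an aromatic carbon. Going by the values given here, this is the same kind of change as the one from compound 1 to compound 3, but the surroundings are not identical: in compound 1 the carbon that loses the methoxy group is meta to a methoxy group, whereas in compound 2 it is meta to a hydroxy group. Because of the step of a number 29 percentage points higher from compound 1 to compound 3 (beyond the scatter) seen in compound 1, a step in the same direction is expected for compound 4, though the room upward is limited since a reading cannot rise much past full activity. The expected step from compound 2 is a number 21 percentage points higher from compound 2 to compound 4 (beyond the scatter). Compound 4 is therefore estimated to give 80% in this assay, most likely between 62% and 97%.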

Compound 4, a percentage reported as activity, at one concentration (the size of the read-out at that concentration, not a potency): 19%
The estimate for compound 4 lay 61 percentage points above the measured number; measured number outside the range, below it.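

In this assay hydrogen in place of methoxy on an aromatic carbon gave a number 40 percentage points lower from compound 2 to compound 4 (beyond the scatter) and so a stronger effect, whereas the same change on the other core gave a number 29 percentage points higher from compound 1 to compound 3 (beyond the scatter) and so a weaker one. This shows that in this series the direction of the step did not carry over from one core to the other, so a step seen on one core is no safe guide to what the same change will do on another. With one pair on each core, it does not show whether the reversal comes from the cores themselves or from the groups around the changed carbon, and nothing shown here bears on the reason for it.

The compounds shown leave open how other replacements for the methoxy group would behave on these two cores, for example an amine, a chlorine atom or a longer chain such as ethoxy. They also leave open which of the two opposite steps a third core would follow, and whether the same change at another carbon of the ring would give a step in the same direction.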